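Furan-2-yl at the chain carbon: working notes

A few compounds are considered here, and "the series" means these few. Any claim that something is new, unique, unknown or untested is made for them only; others in the source may bear on it.

compound 1 `O=C1C(=Cc2ccc(Br)cc2)C(=O)N(c2ccc(Cl)cc2)N1c1ccc(Cl)cc1` gives 16900 nM
compound 2 `COc1ccccc1C=C1C(=O)N(c2ccc(Cl)cc2)N(c2ccc(Cl)cc2)C1=O` gives 28600 nM

Both numbers come from a functional assay on MGC-803 cells (Homo sapiens) for cytotoxicity, read by MTT assay, with a stated time of 72 h (on this read-out higher numbers stand for weaker inhibition and lower numbers for stronger inhibition), and are the only ones so far. Among the measured compounds shown here, compound 2 stands level with compound 1 within the scatter, as the single measured step shows: a 1.7-fold higher number from compound 1 to compound 2 (0.23 log units; within the scatter) and no more.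

Next is compound 3 `O=C1C(=Cc2ccco2)C(=O)N(c2ccc(Cl)cc2)N1c1ccc(Cl)cc1` with the change furan-2-yl in place of 2-methoxyphenyl on a double-bonded chain carbon bound to a double-bonded ring carbon in one place: furan-2-yl in place of 2-methoxyphenyl on a double-bonded chain carbon bound to a double-bonded ring carbon.

For the measured compounds named here, only one measured step bears on this. That step, a 1.7-fold higher number from compound 1 to compound 2 (0.23 log units; within the scatter) also replaced the group at this place, with 2-methoxyphenyl in place of 4-bromophenyl, and it stayed within the scatter. Going by the values given here, no compound with furan-2-yl has been measured, so this support is thin.

In this assay no step beyond the scatter is expected in either direction. The estimated step is a 1.3-fold lower number from compound 2 to compound 3 (0.11 log units; within the scatter) and that is a small expected change. Compound 3 is estimated at 22000 nM with an expected range from 9000 nM to 50000 nM as the working figure.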

Compound 3, half-maximal inhibitory concentration: 12800 nM
For compound 3 the middle estimate is 1.7-fold (0.24 log units) above the measured one; the measured number falls inside the stated range.
By their numbers in this assay, from the lowest: compounds 3, 1 and 2 (each within the scatter of the next, the first and the last beyond it).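

In this assay, among the compounds shown here, the step of a 2.2-fold lower number from compound 2 to compound 3 (0.35 log units; beyond the scatter) is the first to pass the scatter, though only modestly, and it shows that the double-bonded chain carbon can carry a five-membered aromatic ring with 1 hetero atom in place of a six-membered aromatic ring of carbon only without any loss in this cell read-out. The step of a 1.3-fold lower number from compound 1 to compound 3 (0.12 log units; within the scatter) gives no separation, so furan-2-yl and 4-bromophenyl stand level at this place, and the only gap beyond the scatter at this position lies between furan-2-yl and 2-methoxyphenyl. No measurement at hand accounts for that gap.

As far as these compounds go, whether this place accepts anything other than an aromatic ring remains open, for instance an amine, a carboxylic acid or a longer chain on the chain carbon. From the compounds shown here alone, all three compounds share the rest of the core, so it also remains open whether the level standing of furan-2-yl and 4-bromophenyl and the gap to 2-methoxyphenyl would hold with other groups elsewhere on it.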